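Piperidine Amide in Place of the 2-Methylbenzyl Amide

The source may report more compounds than this note shows. Statements on the series, on what has been measured and on what is new or still open speak of the compounds shown alone.

Compound 3 `Cc1ccccc1CNC(=O)c1nn(-c2ccc(F)cc2)c(OC[C@@H](O)C[C@@H](O)CC(=O)O)c1C(C)C` gives 17 nM in an assay on microsomes from liver for inhibition of 3-hydroxy-3-methylglutaryl-coenzyme A reductase (Rattus norvegicus); on this read-out lower numbers stand for stronger inhibition and higher numbers for weaker inhibition. It stands level with compound 1 `CC(C)c1c(C(=O)NCC2CCCCC2)nn(-c2ccc(F)cc2)c1OC[C@@H](O)C[C@@H](O)CC(=O)O`, which gives 17 nM, and the pair are the highest of the three numbers; compound 2 `Cc1ccc(CNC(=O)c2nn(-c3ccc(F)cc3)c(OC[C@@H](O)C[C@@H](O)CC(=O)O)c2C(C)C)cc1` gives 15 nM, with a 1.1-fold higher number from compound 2 to compound 3 (0.05 log units; within the scatter). The step of no change at the digits printed from compound 1 to compound 3 (within the scatter) and the step of a 1.1-fold lower number from compound 1 to compound 2 (0.05 log units; within the scatter) both stay within the scatter. Compound 4 `CC(C)c1c(C(=O)N2CCCCC2)nn(-c2ccc(F)cc2)c1OC[C@@H](O)C[C@@H](O)CC(=O)O` differs from compound 3 by piperidin-1-yl in place of (2-methylbenzyl)amino on a carbonyl carbon. Going by the values given here, no measured step alters this part: each varied only the group on the carbon bound to the amide-type nitrogen, and all stayed within the scatter. The change for compound 4 removes that carbon and the hydrogen-bond donor, so a modest rise toward weaker inhibition is expected, as a 2.6-fold higher number from compound 3 to compound 4 (0.42 log units; beyond the scatter). For compound 4 the expected value is 45 nM, between 12 nM and 170 nM.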

Compound 4, half-maximal inhibitory concentration: 47 nM
Compound 4: middle estimate off by 1.0-fold (0.02 log units), on the low side; measured number inside the range.
By their numbers in this assay, from the lowest: compounds 2, 1 and 3 (each within the scatter of the next); then compound 4.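

Among the earlier compounds, changing the group on the carbon bound to the amide-type nitrogen gave only steps within the scatter, but piperidin-1-yl in place of the whole amino group shifts the read-out in this assay. The numbers rise in every comparison (a 2.8-fold higher number from compound 3 to compound 4 (0.44 log units; beyond the scatter); a 3.1-fold higher number from compound 2 to compound 4 (0.50 log units; beyond the scatter); a 2.8-fold higher number from compound 1 to compound 4 (0.44 log units; beyond the scatter)), so the position tolerates varied groups yet does respond to this change. The loss of the amide hydrogen and the change of ring cannot be told apart, and no supporting measurement bears on either. A dimethylamino or methylamino group on the same carbonyl carbon could help separate them.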